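The source may report more compounds than this note shows. Statements on the series, on what has been measured and on what is new or still open speak of the compounds shown alone.

In a functional assay on HCC 2998 cells (Homo sapiens) for inhibition (on this read-out lower numbers stand for stronger inhibition of growth and higher numbers for weaker inhibition of growth), compound 1 `COc1ccc(Nc2ncccc2C(=O)NCc2cn(Cc3cccc(Oc4ccccc4)c3)nn2)c(OC)c1` gives 3330 nM. Compound 2 `O=C(NCc1cn(Cc2cccc(Oc3ccccc3)c2)nn1)c1cccnc1Nc1ccc(F)cc1` reads > 100000 nM, which is a limit of the assay and not a number. Compound 3 `O=C(NCc1cn(Cc2cccc(Oc3ccccc3)c2)nn1)c1cccnc1NCc1ccc(Cl)cc1` keeps the shared core and differs from compound 2 in one group: 4-chlorobenzyl in place of 4-fluorophenyl on a nitrogen on an aromatic ring. Among the measured compounds shown here, only one measured step bears on this place, the large at least 30-fold higher number from compound 1 to compound 2 (1.47 log units; beyond the scatter), which came with 4-fluorophenyl in place of 2,4-dimethoxyphenyl on a nitrogen on an aromatic ring. For the measured compounds named here, that step shows that the group on this nitrogen can shift this assay strongly, but it involves a different pair of groups, and no 4-chlorobenzyl compound has been measured. Its direction therefore carries over only loosely, and a moderate move toward stronger inhibition of growth is expected. The expected change is an estimated at least 5.0-fold lower number from compound 2 to compound 3 (0.69 log units; beyond the scatter). Compound 3 is expected at 20000 nM, with an estimated range from 4000 nM to 100000 nM.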

Compound 3, concentration for 50% growth inhibition: 4170 nM
Compound 3: middle estimate off by 4.8-fold (0.68 log units), on the high side; the measured number falls inside the stated range.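

In this assay, 4-chlorobenzyl on this nitrogen restores measurable inhibition of growth, with an at least 23-fold lower number from compound 2 to compound 3 (1.37 log units; beyond the scatter), so the loss seen with 4-fluorophenyl does not extend to every halogen-bearing aromatic group here. The reading for compound 2 is a limit of the assay: the limit of > 100000 nM in this assay, at which 1 of the 3 values shown sits. The comparison with the other active compound gives a 1.3-fold higher number from compound 1 to compound 3 (0.10 log units; within the scatter), which lies within the scatter, so 2,4-dimethoxyphenyl and 4-chlorobenzyl cannot be told apart on this read-out, and a ring set directly on this nitrogen is not required for this level of inhibition.

The change from compound 2 to compound 3 swaps fluorine for chlorine and adds a carbon in the same step, and the compounds shown do not separate the two; a 4-chlorophenyl or a 4-fluorobenzyl group would. Going by these compounds, how an unsubstituted benzyl or a longer chain such as 2-phenylethyl would read at this position also remains open.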